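Swapping a pyridine for a thiophene on a shared core

The source may report more compounds than this note shows. Statements on the series, on what has been measured and on what is new or still open speak of the compounds shown alone.

Compound 1 `Oc1cccc(-c2cc(-c3ccncc3)nc(-c3cccc(Cl)c3)c2)c1` has no number in a functional assay on HCT-15 cells (Homo sapiens) for cytotoxicity, read by CCK-8 assay and cell counting, with a stated time of 2 days; a higher number here means a weaker inhibitor, a lower number a stronger inhibitor; for compound 1 the record reads "not determined" (no result reported). A related compound 2 `Oc1cccc(-c2cc(-c3cccs3)nc(-c3ccccc3Cl)c2)c1`, which differs at two places, gives 2790 nM in this assay. Compound 3 `Oc1cccc(-c2cc(-c3ccsc3)nc(-c3cccc(Cl)c3)c2)c1` differs from compound 1 by one change, (thiophen-3-yl in place of pyridin-4-yl on an aromatic carbon). For the measured compounds named here, no measured step from compound 1 to compound 3 exists, so the expectation rests on compound 2 alone, and a value near it, within the usual scatter, is expected. Compound 3 is estimated at 2500 nM in this assay, with a range from 800 nM to 8000 nM.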

Compound 3, half-maximal inhibitory concentration: 2510 nM
Estimate against measurement, compound 3: 1.0-fold (0.00 log units) below; the measured number falls inside the stated range.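

For the compounds shown here, no step from compound 1 to compound 3 can be read in this assay. From the compounds shown here alone, what thiophen-3-yl in place of pyridin-4-yl does on the shared core stays open. No other evidence bears on this result.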